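Trifluoromethyl in place of cyano on the benzyl group

The source may hold more compounds than are shown below. What is called first, only, known or untested is meant among the compounds shown, and "the series" means these compounds.

Three compounds have been measured in a functional assay on RAW264.7 cells (Mus musculus) for inhibition, read by Griess assay, with stated times of 2 h and 24 h; on this read-out higher numbers stand for weaker inhibition and lower numbers for stronger inhibition:
compound 1, `COc1ccc([C@@H]2CC(=O)c3c(O)cc(OCc4cn(Cc5ccccc5F)nn4)cc3O2)cc1O`, gives 7320 nM;
compound 2, `COc1ccc([C@@H]2CC(=O)c3c(O)cc(OCc4cn(Cc5ccccc5C#N)nn4)cc3O2)cc1O`, gives 14600 nM;
compound 3, `COc1ccc([C@@H]2CC(=O)c3c(O)cc(OCc4cn(Cc5cccc(C#N)c5)nn4)cc3O2)cc1O`, gives 18000 nM.

Compound 3 holds the highest of these three numbers. Its nearest neighbour is compound 2, and that gap is a 1.2-fold higher number from compound 2 to compound 3 (0.09 log units; within the scatter). The other gap is a 2.5-fold higher number from compound 1 to compound 3 (0.39 log units; beyond the scatter), which is modest but beyond the scatter.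

Compound 4, `COc1ccc([C@@H]2CC(=O)c3c(O)cc(OCc4cn(Cc5cccc(C(F)(F)F)c5)nn4)cc3O2)cc1O`, carries one change from compound 3: trifluoromethyl in place of cyano on an aromatic carbon. For the measured compounds named here, no measured step exchanges cyano for trifluoromethyl. Going by the values given here, the steps that bear on it are the replacements at this same benzyl group: a 2.0-fold higher number from compound 1 to compound 2 (0.30 log units; within the scatter), a 2.5-fold higher number from compound 1 to compound 3 (0.39 log units; beyond the scatter) and a 1.2-fold higher number from compound 2 to compound 3 (0.09 log units; within the scatter). All of them are small, and none of them shows a change between two substituents on the ring that moves the number far. Compound 4 is therefore expected to sit close to compound 3, with a step of a 1.1-fold lower number from compound 3 to compound 4 (0.02 log units; within the scatter), and no change beyond the scatter is expected in either direction. The estimate for compound 4 is 17000 nM, within a range from 7000 nM to 42000 nM.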

Compound 4, half-maximal inhibitory concentration: 19900 nM
Beside the measured number, compound 4's estimate is 1.2-fold (0.07 log units) below it, within the range that was stated.
By their numbers in this assay, from the lowest: compounds 1, 2, 3 and 4 (each within the scatter of the next, the first and the last beyond it).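

In this assay, the step to trifluoromethyl is a 1.1-fold higher number from compound 3 to compound 4 (0.04 log units; within the scatter), so this place on the aromatic ring accepts a group of four heavy atoms and no hydrogen-bond acceptor in exchange for the nitrile without a change that can be told from the scatter. The other two new steps are a 1.4-fold higher number from compound 2 to compound 4 (0.13 log units; within the scatter) and a 2.7-fold higher number from compound 1 to compound 4 (0.43 log units; beyond the scatter), and only the second lies beyond the scatter, which sets compound 4 with compound 3 as differing from compound 1 by a modest step. Nothing available explains why the exchange leaves the number so little moved.

As far as these compounds go, it remains open whether an amine or a carboxylic acid at this place would move the number beyond the scatter from compound 3. From the compounds shown here alone, it is also open whether the step from compound 1 follows from the fluoro group itself or from where that group sits on the ring.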